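The source may hold more compounds than are shown below. What is called first, only, known or untested is meant among the compounds shown, and "the series" means these compounds.

Measured so far in a functional assay on SR cells (Homo sapiens) for inhibition, read by sulforhodamine B assay, with a stated time of 48 h, tested at 100 uM; a higher number here means a weaker effect of the compound at the concentration tested, a lower number a stronger effect:
- compound 1, `O=C(Nc1cccc(-n2cc(-c3ccncc3)c(-c3cc(O)cc(Cl)c3)n2)c1)Nc1ccc(Cl)c(C(F)(F)F)c1`, gives -40%.
- compound 2, `COc1cc(Cl)cc(-c2nn(-c3cccc(NC(=O)Nc4cc(C(F)(F)F)cc(C(F)(F)F)c4)c3)cc2-c2ccncc2)c1`, gives -8%.

Compound 2 stands highest of the two numbers; its nearest neighbour is compound 1, whose value lies lower by a gap beyond the scatter. For the measured compounds named here, no step between measured compounds that differ in one place is available, so the two values show only that compound 1 reads lower than compound 2 in this assay and offer no direct guide for the change at hand.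

Compound 3, `COc1cc(Cl)cc(-c2nn(-c3cccc(NC(=O)Nc4cccc(C(F)(F)F)c4)c3)cc2-c2ccncc2)c1`, is not yet measured. It differs from compound 2 in one place: hydrogen in place of trifluoromethyl on an aromatic carbon. Going by the values given here, the effect of removing a single trifluoromethyl is unknown, as no pair of measured compounds differs in that way. For this assay a step of modest size is expected, most likely toward a lower number, though it may well remain within the scatter. The estimate for compound 3 is -15%, with a range from -45% to 15%. The expected step, not an observed one, is a number 7 percentage points lower from compound 2 to compound 3 (within the scatter).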

Compound 3, a percentage reported as activity, at one concentration (the size of the read-out at that concentration, not a potency): -30%
Compound 3: the middle estimate sits 15 percentage points above what was measured, within the range that was stated.
By their numbers in this assay, from the lowest: compounds 1 and 3 (each within the scatter of the next); then compound 2.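

In this assay, the series now has its first step between compounds differing in one place: hydrogen in place of trifluoromethyl on an aromatic carbon, meta to a large group and meta to the trifluoromethyl group that remains, gives a number 22 percentage points lower from compound 2 to compound 3 (beyond the scatter). This shows that the position is not indifferent to the change, and that the stronger effect at the concentration tested does not depend on a trifluoromethyl group at this carbon. The finding rests on this single pair, and nothing at hand explains the size or direction of the step.

Going by these compounds, it remains open whether a nitrile, a methoxy group, an amine or a single fluorine on this carbon would read closer to hydrogen or to trifluoromethyl. Also open, on these data alone, is whether the same replacement gives a comparable step when a hydroxyl takes the place of the methoxy group on the chlorinated ring.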